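Replacing 4-bromophenyl with ethynyl on the sulfur chain

The compounds below may be only part of what the source reports. "The series", "measured", "known", "first", "only" and "open" are said of these compounds alone.

Values so far in a functional assay on MGC-803 cells (Homo sapiens) for inhibition, read by MTT assay, with a stated time of 72 h (on this read-out lower numbers stand for stronger inhibition and higher numbers for weaker inhibition), follow
- compound 1 `Cc1cc(Nc2cc(-c3ccccc3)[nH]n2)n2nc(SCc3c(Cl)cccc3Cl)nc2n1` gives 5280 nM
- compound 2 `Cc1cc(Nc2cc(-c3cccs3)[nH]n2)n2nc(SCc3ccc(Br)cc3)nc2n1` gives 3770 nM
- compound 3 `Cc1cc(Nc2cc(-c3ccccc3)[nH]n2)n2nc(SCc3ccc(Br)cc3)nc2n1` gives 1110 nM

Compound 3 has the lowest of these three numbers. The next compound to be read is compound 4 `C#CCSc1nc2nc(C)cc(Nc3cc(-c4ccccc4)[nH]n3)n2n1`, which keeps the phenyl of compound 3 and changes the other end of the molecule: ethynyl in place of 4-bromophenyl on a saturated chain carbon bound to a sulfur. In words, this is ethynyl in place of 4-bromophenyl on a saturated chain carbon bound to a sulfur.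

The nearest evidence is at this same place, where the data show a 4.8-fold lower number from compound 1 to compound 3 (0.68 log units; beyond the scatter) as a modest step between two substituted phenyl groups. The step of a 3.4-fold lower number from compound 2 to compound 3 (0.53 log units; beyond the scatter) lies on an aromatic carbon and bears on the change only indirectly. Within the data shown here, no measured compound carries ethynyl here, so the direction is uncertain. A modest move toward a higher number is expected, and the estimated step is a 3.6-fold higher number from compound 3 to compound 4 (0.56 log units; beyond the scatter) in this assay as the working expectation. For compound 4 the estimated value is 4000 nM with an expected range of 1300 nM to 13000 nM on this read-out.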

Compound 4, half-maximal inhibitory concentration: 13400 nM
Compound 4: middle estimate off by 3.4-fold (0.53 log units), on the low side, outside the stated range (above it).
By their numbers in this assay, from the lowest: compound 3; then compounds 2 and 1 (each within the scatter of the next); then compound 4.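

In this assay, among these compounds, the step at the sulfur chain is large when the 4-bromophenyl gives way to ethynyl (a 12-fold higher number from compound 3 to compound 4 (1.08 log units; beyond the scatter)), whereas the only earlier step at this place, between two substituted phenyl groups, was modest. Ethynyl also falls behind the 2,6-dichlorophenyl group (a 2.5-fold higher number from compound 1 to compound 4 (0.40 log units; beyond the scatter)), so compound 1 and compound 3, which both carry a halogenated phenyl on the saturated chain carbon, each give a lower number than compound 4. No measurement at hand accounts for these steps.

The compounds shown leave open whether the aromatic ring or its halogen carries the difference, which an unsubstituted benzyl or a plain propyl on the sulfur would help to separate. Also open, as far as these compounds go, is how a longer chain or a terminal amine on the sulfur would read here.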